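Aryl swap on the bromoacrylamide core

The source may hold more compounds than are shown below. What is called first, only, known or untested is meant among the compounds shown, and "the series" means these compounds.

Compound 2 `C=C(Br)C(=O)Nc1cccc(-c2cn3nc(-c4ccc(CC)cc4)sc3n2)c1` holds the lowest number of the three measured in a functional assay on FM3A cells (Mus musculus) for inhibition, read by cell counting, with a stated time of 2 days (a higher number here means a weaker inhibitor, a lower number a stronger inhibitor), where compound 2 gives 3300 nM. Its nearest neighbour is compound 3 `Nc1cccc(-c2cn3nc(Cc4ccc(Cl)cc4)sc3n2)c1`, which in this assay gives 6000 nM; the two values lie within the scatter of each other, so no order between them is claimed. The furthest is compound 1 `CCc1ccc(-c2nn3cc(-c4cccc(N)c4)nc3s2)cc1`, which gives 8200 nM. Among the measured compounds shown here, the only single-point step measured runs a 2.5-fold lower number from compound 1 to compound 2 (0.40 log units; beyond the scatter).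

Compound 4 `C=C(Br)C(=O)Nc1cccc(-c2cn3nc(-c4cccc(OC)c4)sc3n2)c1` differs from compound 2 by 3-methoxyphenyl in place of 4-ethylphenyl on an aromatic carbon. For the measured compounds named here, no measured pair isolates this change: compound 3 differs from compound 2 at two places and cannot be read against it, and the step from compound 1 to compound 2 concerns the amide, not the aryl group. The measured step therefore gives no direction for the aryl exchange, and an expectation for compound 4 can only rest on the value of compound 2 with a widened range. Compound 4 is expected to give about 3500 nM in this assay, with a range from 1200 nM to 10000 nM. The step from compound 2 to compound 4 is thus estimated as a 1.1-fold higher number from compound 2 to compound 4 (0.03 log units; within the scatter), a change not beyond the scatter in either direction.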

Compound 4, half-maximal inhibitory concentration: 500 nM
Estimate against measurement, compound 4: 7.0-fold (0.85 log units) above; the measured number lies below the stated range.
By their numbers in this assay, from the lowest: compound 4; then compounds 2, 3 and 1 (each within the scatter of the next, the first and the last beyond it).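

In this assay, the exchange of 4-ethylphenyl for 3-methoxyphenyl on the aromatic carbon of the five-membered ring gives a 6.6-fold lower number from compound 2 to compound 4 (0.82 log units; beyond the scatter), with the (1-bromoethenyl)carbonyl amide left in place. Among the compounds shown here, the earlier single-place comparison concerned only the group on the nitrogen, a 2.5-fold lower number from compound 1 to compound 2 (0.40 log units; beyond the scatter), so this is the first measured sign that the number also responds to the aryl group at this position, and compound 4 is the only compound here that stands beyond the scatter of its one-place neighbour by this exchange. No evidence is available on the origin of this step, which remains an observed difference between two compounds.

The exchange alters both the substituent and where it stands on the phenyl ring, so the compounds shown do not separate these two parts of the step. Also open, from the compounds shown here alone, are how this position responds to a phenyl ring carrying an amine or a carboxylic acid, and whether 3-methoxyphenyl gives a comparable step when hydrogen replaces the (1-bromoethenyl)carbonyl group on the nitrogen.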